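Chloro to fluoro on the pyrazole aryl of compound 2

This account rests on a few compounds, and the source may have more. Where it says the series, first, only, none or still open, it means among the compounds named here.

Three compounds of the series have numbers in a functional assay on MGC-803 cells (Homo sapiens) for inhibition, read by MTT assay, with a stated time of 72 h; on this read-out lower numbers stand for stronger inhibition and higher numbers for weaker inhibition. Compound 1 `Cc1cc(Nc2cc(-c3ccccc3)[nH]n2)n2nc(SCc3c(Cl)cccc3Cl)nc2n1` gives 5280 nM, compound 3 `Cc1cc(Nc2cc(-c3ccccc3)[nH]n2)n2nc(SCc3cccc4ccccc34)nc2n1` gives 3120 nM, and compound 2 `Cc1cc(Nc2cc(-c3ccc(Cl)cc3)[nH]n2)n2nc(SCc3ccc(Br)cc3)nc2n1` gives 2780 nM. Compound 2 holds the lowest of the three numbers, yet both its neighbours sit within the scatter of it, so no order among the three can be read. Within the data shown here, the one step within the measured set, a 1.7-fold lower number from compound 1 to compound 3 (0.23 log units; within the scatter), concerns the group on the saturated chain carbon bound to sulfur and does not touch the aryl on the pyrazole.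

Compound 4 `Cc1cc(Nc2cc(-c3ccc(F)cc3)[nH]n2)n2nc(SCc3ccc(Br)cc3)nc2n1` differs from compound 2 by fluoro in place of chloro on an aromatic carbon. Among the measured compounds shown here, no measured pair isolates this change: compounds 1 and 3 carry an unsubstituted phenyl there, but they also differ from compound 2 at the thioether side. Given that the only measured step, a 1.7-fold lower number from compound 1 to compound 3 (0.23 log units; within the scatter), stayed within the scatter, the expected step of a 1.3-fold higher number from compound 2 to compound 4 (0.10 log units; within the scatter) is none beyond the scatter. Compound 4 is therefore estimated at 3500 nM, with a range from 1500 nM to 8000 nM.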

Compound 4, half-maximal inhibitory concentration: 2210 nM
Beside the measured number, compound 4's estimate is 1.6-fold (0.20 log units) above it, and the stated range covers the measured number.
By their numbers in this assay, from the lowest: compounds 4, 2, 3 and 1 (each within the scatter of the next, the first and the last beyond it).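

In this assay, among these compounds, the change from 4-chlorophenyl to 4-fluorophenyl gives a 1.3-fold lower number from compound 2 to compound 4 (0.10 log units; within the scatter), and this is the only measured pair that isolates a change on this aryl. Among the compounds shown here, with the thioether side held fixed, exchanging one halogen for the other at this aromatic carbon does not move the number beyond the scatter, so this pair separates chloro from fluoro no more than the earlier compounds did. No measurement here bears on the reason for this result.

Going by these compounds, whether a group of another kind at this place, such as methoxy, an amine or a carboxylic acid, would move the number beyond the scatter remains open. The unsubstituted phenyl also has no clean comparison with either halogen: compound 1 and compound 3 differ from compound 2 and compound 4 on the thioether side as well.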